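Trifluoromethyl added to the chloro-anilide of compound 1

This account rests on a few compounds, and the source may have more. Where it says the series, first, only, none or still open, it means among the compounds named here.

Compound 1 `CN(C)C(=O)c1cc2cnc(Nc3ccc(NC(=O)C4(C(=O)Nc5ccc(Cl)cc5)CC4)cc3)nc2n1C1CCCC1` holds the highest of the three numbers in a functional assay on NCI-H1299 cells (Homo sapiens) for inhibition, read by CCK-8 assay, with a stated time of 72 h, tested at 10 uM (on this read-out lower numbers stand for less inhibition of growth and higher numbers for more inhibition of growth at the one concentration tested), where compound 1 gives 88.6%. Compound 2 `CN(C)C(=O)c1cc2cnc(Nc3ccc(NC(=O)C4(C(=O)Nc5cccc(F)c5)CC4)cc3)nc2n1C1CCCC1` gives 87%, and compound 3 `CN(C)C(=O)c1cc2cnc(Nc3ccc(NC(=O)C4(C(=O)Nc5cccc(O)c5)CC4)cc3)nc2n1C1CCCC1` gives 78.5%. The step of a number 1.6 percentage points lower from compound 1 to compound 2 (within the scatter) lies within the scatter, the step of a number 10.1 percentage points lower from compound 1 to compound 3 (beyond the scatter) is a modest loss, and the step of a number 8.5 percentage points lower from compound 2 to compound 3 (within the scatter) again lies within the scatter.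

Compound 4 `CN(C)C(=O)c1cc2cnc(Nc3ccc(NC(=O)C4(C(=O)Nc5ccc(Cl)c(C(F)(F)F)c5)CC4)cc3)nc2n1C1CCCC1` keeps the core and the chloro group of compound 1 and differs by trifluoromethyl in place of hydrogen on an aromatic carbon. For the measured compounds named here, none of the measured steps adds a group while leaving the chloro group in place; each exchanges the ring substituent for another, and the largest of them, a number 10.1 percentage points lower from compound 1 to compound 3 (beyond the scatter), is only modest. The measured series therefore gives no ground to expect a step beyond the scatter in this assay for compound 4; the expected step is a number 1.6 percentage points lower from compound 1 to compound 4 (within the scatter). Compound 4 is estimated at 87%, with a range from 78% to 94%.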

Compound 4, percent growth inhibition at one concentration: 90.4%
Beside the measured number, compound 4's estimate is 3.4 percentage points below it; low and high end bracket the measured number.
By their numbers in this assay, from the lowest: compounds 3, 2, 1 and 4 (each within the scatter of the next, the first and the last beyond it).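

In this assay, for the compounds shown here, the position ortho to a chloro group accepts trifluoromethyl with the chloro group left in place, a kind of change the earlier steps did not cover (a number 1.8 percentage points higher from compound 1 to compound 4 (within the scatter)). Compared with the other two anilides, the results are (a number 3.4 percentage points higher from compound 2 to compound 4 (within the scatter)) and (a number 11.9 percentage points higher from compound 3 to compound 4 (beyond the scatter)), so compound 3 now lies beyond the scatter of two of the other three compounds. No measurement bears on why this position accepts the added group.

Still open, from the compounds shown here alone, is whether trifluoromethyl gives the same result at this position without the chloro group. Going by these compounds, it is also open whether an aminomethyl group or a carboxylic acid in place of trifluoromethyl would keep the number within the scatter of compound 1.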